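Adding a methyl to the lactam ring carbon of compound 2

The source may report more compounds than this note shows. Statements on the series, on what has been measured and on what is new or still open speak of the compounds shown alone.

Measured compounds:
compound 1, `CCC(=O)N[C@@H]1CCCc2c1cncc2N1C(=O)c2ccc(Cl)cc2[C@@H]1C`, 6 nM
compound 2, `CC(=O)N[C@@H]1CCCc2c1cncc2N1C(=O)c2ccc(Cl)cc2[C@@H]1C`, 4 nM
compound 3, `Cc1ccncc1C(=O)N1CC2(C1)CN(c1cncc(N3C(=O)c4ccc(Cl)cc4C3(C)C)c1)C2`, 14 nM

In an assay on cells for inhibition of cytochrome P450 11B2, mitochondrial (Homo sapiens), read by HTRF (a lower number here means a stronger inhibitor, a higher number a weaker inhibitor), compound 2 gives 4 nM, the low end of the three numbers. Compound 1 sits nearby: the change a 1.5-fold lower number from compound 1 to compound 2 (0.18 log units; within the scatter) is a small one on the acyl side chain. Compound 3, with its different core, gives 14 nM, a gap that lies beyond the scatter.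

The unmeasured compound 4, `CC[C@H]1c2cc(Cl)ccc2C(=O)N1c1cncc2c1CCC[C@H]2NC(C)=O`, differs from compound 2 by one change: methyl in place of hydrogen on a saturated chain carbon bound to a saturated ring carbon. Among the measured steps only the one from compound 1 to compound 2 is a single change, and it sits at another place, so no measured step bears directly on this change. For the measured compounds named here, the only guide is that one added carbon elsewhere left this assay within the scatter, and compound 3, carrying two methyls at the same ring carbon on a different core, stays within a modest distance. Compound 4 is therefore expected to change by a 1.5-fold higher number from compound 2 to compound 4 (0.18 log units; within the scatter), a step not clearly beyond the scatter. The estimate for compound 4 is 6 nM, with a range from 2 nM to 20 nM.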

Compound 4, half-maximal inhibitory concentration: 97 nM
Compound 4: the middle estimate sits 16-fold (1.21 log units) below what was measured; measured number outside the range, above it.
By their numbers in this assay, from the lowest: compounds 2 and 1 (each within the scatter of the next); then compound 3; then compound 4.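

In this assay, lengthening methyl to ethyl on this saturated chain carbon bound to a saturated ring carbon gives a 24-fold higher number from compound 2 to compound 4 (1.38 log units; beyond the scatter) and so weakens the inhibitor clearly with just one added carbon. One carbon's difference on the acyl side chain gives only a 1.5-fold lower number from compound 1 to compound 2 (0.18 log units; within the scatter) and stays within the usual scatter, so the two places in these molecules do not respond alike to a change of this size. The data shown offer no explanation for the sensitivity at this position.

From the compounds shown here alone, it remains open whether the loss grows, levels off or reverses with a longer chain such as propyl or a branched group such as isopropyl. A hydroxymethyl group or an amine on this carbon would show whether chains carrying other atoms fare any better than ethyl.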